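A Cyclopropyl Amide Tested Against Histone Deacetylase 7

The source may hold more compounds than are shown below. What is called first, only, known or untested is meant among the compounds shown, and "the series" means these compounds.

In an assay on isolated protein for inhibition of histone deacetylase 7 (Homo sapiens), tested at 1 uM (a lower number here means less inhibition, a higher number more inhibition at the concentration tested (going by the name of the read-out)), compound 1 `CC(C)(C(=O)Nc1ccc(C(=O)Nc2ccc(F)cc2N)cc1)c1ccccc1` gives 0% and stands level with compound 2 `CC(C)(C(=O)Nc1ccc(C(=O)Nc2ccccc2N)cc1)c1ccccc1`, which gives 0%; the step of no change at the digits printed from compound 1 to compound 2 (within the scatter), hydrogen in place of fluoro on an aromatic carbon, lies within the scatter. Compound 3 `Nc1cc(F)ccc1NC(=O)c1ccc(NC(=O)C2CC2c2ccccc2)cc1` differs from compound 1 by 2-phenylcyclopropyl in place of 1-methyl-1-phenylethyl on a carbonyl carbon. Among the measured compounds shown here, no measured step touches the carbonyl carbon, so only the flat readings of compound 1 and compound 2 guide the expectation, and no step beyond the scatter is expected. Compound 3 is therefore estimated at 5% in this assay, between 0% and 25%. For compound 3 the expected step is a number 5 percentage points higher from compound 1 to compound 3 (within the scatter).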

Compound 3, a percentage reported as inhibition, at one concentration (the size of the read-out at that concentration, not a potency): 0%
Compound 3: middle estimate off by 5 percentage points, on the high side, within the range that was stated.
By their numbers in this assay, from the lowest: compounds 1, 2 and 3 (each within the scatter of the next).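

In this assay, among the compounds shown here, the first change on the carbonyl carbon, 2-phenylcyclopropyl in place of 1-methyl-1-phenylethyl, gives no change at the digits printed from compound 1 to compound 3 (within the scatter). For the compounds shown here, the earlier compounds spoke only to the fluoro on an aromatic carbon, so this is the first reading at this position, and it shows that swapping one all-carbon group for another of the same heavy-atom count leaves the read-out flat. Nothing available accounts for this flat result.

The compounds shown leave open whether an amine or a carboxylic acid on this carbonyl carbon would move the reading at all. They also leave open whether this position can influence inhibition at the tested concentration.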